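Swapping the amide aryl group: nitro to dichloro

The compounds below may be only part of what the source reports. "The series", "measured", "known", "first", "only" and "open" are said of these compounds alone.

Compounds measured so far, with their values in an assay on isolated protein for inhibition of histone deacetylase 4 (Homo sapiens), with a stated time of 1 h; on this read-out lower numbers stand for stronger inhibition and higher numbers for weaker inhibition:
- compound 1, `O=C(COc1ccc2cc(/C=C3/SC(=O)NC3=O)ccc2c1)Nc1ccc(Br)cc1F`: 1900 nM
- compound 2, `O=C(COc1ccc2cc(/C=C3/SC(=O)NC3=O)ccc2c1)Nc1ccccn1`: 17000 nM
- compound 3, `O=C(COc1ccc2cc(/C=C3/SC(=O)NC3=O)ccc2c1)Nc1ccc([N+](=O)[O-])cc1`: 1700 nM

All three share one core and differ only in the group on the amide-type nitrogen. Compound 3 carries the 4-nitrophenyl group. Compound 1, with 4-bromo-2-fluorophenyl, sits within the scatter of compound 3 (a 1.1-fold lower number from compound 1 to compound 3 (0.05 log units; within the scatter)), so the two cannot be told apart on these numbers. Going by the values given here, compound 2, with pyridin-2-yl, stands clearly apart (a 10-fold lower number from compound 2 to compound 3 (1.00 log units; beyond the scatter)), the only step here that lies beyond the scatter.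

Compound 4, `O=C(COc1ccc2cc(/C=C3/SC(=O)NC3=O)ccc2c1)Nc1ccc(Cl)c(Cl)c1`, is not yet measured. It differs from compound 3 in one place: 3,4-dichlorophenyl in place of 4-nitrophenyl on an amide-type nitrogen. Among the compounds with values here, the step that bears most on this is the one from compound 1 to compound 3, where one halogen-bearing phenyl ring was exchanged for the nitrophenyl ring without a change beyond the scatter. Within the data shown here, the only large step seen, an 8.9-fold higher number from compound 1 to compound 2 (0.95 log units; beyond the scatter), involved a ring of a different kind, a pyridin-2-yl, and does not speak to a dichlorophenyl.

On that basis a step within the scatter is expected, a 1.1-fold lower number from compound 3 to compound 4 (0.03 log units; within the scatter), and compound 4 is estimated at 1600 nM, with a range from 600 nM to 4500 nM.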

Compound 4, half-maximal inhibitory concentration: 5500 nM
For compound 4 the middle estimate is 3.4-fold (0.54 log units) below the measured one; measured number above the stated range.
By their numbers in this assay, from the lowest: compounds 3 and 1 (each within the scatter of the next); then compound 4; then compound 2.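

In this assay, the choice of substituted phenyl ring on the amide-type nitrogen turns out to matter: the change to 3,4-dichlorophenyl gives a step beyond the scatter (a 3.2-fold higher number from compound 3 to compound 4 (0.51 log units; beyond the scatter)), and so does the comparison with the 4-bromo-2-fluorophenyl ring (a 2.9-fold higher number from compound 1 to compound 4 (0.46 log units; beyond the scatter)). Going by these compounds alone, compound 4 also remains apart from the pyridin-2-yl compound (a 3.1-fold lower number from compound 2 to compound 4 (0.49 log units; beyond the scatter)), so this position now shows three levels, with compounds 1 and 3 together at the low end, compound 4 in the middle and compound 2 at the high end, where the earlier compounds showed only two. Nothing available on these compounds accounts for the place of the dichlorophenyl ring in this order.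

From the compounds shown here alone, it remains open whether a phenyl ring with a single chlorine would read like compound 4 or like compounds 1 and 3, so the step cannot yet be tied to either chlorine. A phenyl ring carrying an amine or a carboxylic acid, or a cyclohexyl ring on the same nitrogen, would show whether this order extends beyond the four groups shown here.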